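Carbamoyl to Sulfonyl on the Aromatic Ring

The compounds below may be only part of what the source reports. "The series", "measured", "known", "first", "only" and "open" are said of these compounds alone.

Compound 1, `CC(C)c1noc(N2CCN(C(=O)[C@@H]3CCCN(S(=O)(=O)c4ccc(S(=O)(=O)NC5CC5)cc4)C3)CC2)n1`, gives 1000 nM in a functional assay on MIA PaCa-2 cells (Homo sapiens) for inhibition, read by MTT assay, with a stated time of 7 days; a lower number here means a stronger inhibitor, a higher number a weaker inhibitor.
Compound 2, `CCN(CC)C(=O)c1ccc(S(=O)(=O)N2CCC[C@@H](C(=O)N3CCN(c4nc(C(C)C)no4)CC3)C2)cc1`, gives 100 nM in this assay.

For the measured compounds named here, only two compounds have been measured so far, and compound 2 stands with the lowest number, which here means the stronger inhibitor. Going by the values given here, the single step known, a 10-fold lower number from compound 1 to compound 2 (1.00 log units; beyond the scatter), shows that changing the group on the aromatic carbon shifts the result beyond the scatter.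

Compound 3, `CC(C)c1noc(N2CCN(C(=O)[C@@H]3CCCN(S(=O)(=O)c4ccc(S(=O)(=O)C(C)C)cc4)C3)CC2)n1`, has not yet been measured. It differs from compound 2 by isopropylsulfonyl in place of diethylcarbamoyl on an aromatic carbon. Among the compounds with values here, the only step that bears on this change is a 10-fold lower number from compound 1 to compound 2 (1.00 log units; beyond the scatter), in which a sulfur-bearing group was replaced by a carbonyl-bearing group and the number fell. The new group in compound 3 is again sulfur-based, like the group in compound 1, so a number between those of compound 1 and compound 2 in this assay is expected, leaning towards a weaker result than compound 2. The estimate for compound 3 is therefore 400 nM, with a range from 100 nM to 2000 nM, which means an expected step of a 4.0-fold higher number from compound 2 to compound 3 (0.60 log units; beyond the scatter).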

Compound 3, half-maximal inhibitory concentration: 70 nM
Estimate against measurement, compound 3: 5.7-fold (0.76 log units) above, outside the stated range (below it).
By their numbers in this assay, from the lowest: compounds 3 and 2 (each within the scatter of the next); then compound 1.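

The sulfonyl group attached to the aromatic ring does not by itself bring the weaker result. In this assay, isopropylsulfonyl and diethylcarbamoyl on this aromatic carbon, para to a large group, give a 1.4-fold lower number from compound 2 to compound 3 (0.15 log units; within the scatter) and so cannot be told apart, even though one group is built on sulfur and the other on a carbonyl. The large change lies instead in what the sulfonyl sulfur carries: with isopropyl in place of cyclopropylamino, the result is a 14-fold lower number from compound 1 to compound 3 (1.15 log units; beyond the scatter) and this step stands clear of the scatter, so the difference seen with compound 1 belongs to the cyclopropylamino group and not to the sulfur-based link as a whole. Nothing measured here gives a reason for either step.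

The compounds shown leave open how far the group on the sulfonyl sulfur can vary, for instance whether a longer chain such as n-butyl would behave like isopropyl or whether a plain amino group would behave like cyclopropylamino. They also leave open whether a quite different group on this aromatic carbon, such as a carboxylic acid or a nitrile, would match the values of compound 2 and compound 3.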